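The source may hold more compounds than are shown below. What is called first, only, known or untested is meant among the compounds shown, and "the series" means these compounds.

Compounds measured so far:
- compound 1 `CCCNC(=O)c1ccc2c(ccn2-c2ncc3c(n2)N(C2CCCC2)[C@H](CC)C(=O)N3C)c1`: 238 nM
- compound 2 `CCC1C(=O)N(C)c2cnc(-n3ccc4cc(F)ccc43)nc2N1c1ccn(C)n1`: "not active" (no number reported)
- compound 3 `CCCCNS(=O)(=O)c1ccc(Nc2ncc3c(n2)N(C2CCCC2)[C@H](CC)C(=O)N3C)cc1`: 451 nM

In a functional assay on HeLa cells (Homo sapiens) for antiproliferative activity, read by CCK-8 assay, with a stated time of 72 h (a lower number here means a stronger inhibitor of growth, a higher number a weaker inhibitor of growth), compound 3 gives 451 nM, the higher of the two numbers recorded. Its nearest neighbour is compound 1, which in this assay gives 238 nM; the gap between the two lies within the scatter of repeated measurements, so the two compounds cannot be ranked against each other. Compound 2 is reported in this assay only as "not active" (no number reported), with no number attached.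

Compound 4 `CC[C@@H]1C(=O)N(C)c2cnc(Nc3ccc(S(=O)(=O)Nc4ccccc4)cc3)nc2N1C1CCCC1` has not yet been measured. It differs from compound 3 in one place: phenyl in place of butyl on a sulfonamide nitrogen. Within the data shown here, no pair of measured compounds shows the effect of this change, and no step between measured compounds has been recorded at all, so the expectation for compound 4 rests only on the number for compound 3. The expected step of a 1.1-fold lower number from compound 3 to compound 4 (0.05 log units; within the scatter) is small, with no direction beyond the scatter. Compound 4 is therefore estimated at 400 nM in this assay, within a range from 140 nM to 1200 nM.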

Compound 4, concentration for 50% growth inhibition: 5140 nM
Compound 4: middle estimate off by 13-fold (1.11 log units), on the low side, and the stated range ends below it.
By their numbers in this assay, from the lowest: compounds 1 and 3 (each within the scatter of the next); then compound 4.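

In this assay, phenyl in place of butyl on a sulfonamide nitrogen gives an 11-fold higher number from compound 3 to compound 4 (1.06 log units; beyond the scatter), so this position does not accept every group equally. Among these compounds, the earlier compounds offered no step between neighbours, and this pair is the first to show that a single change in one place on the shared core can move growth inhibition beyond the scatter. Nothing available here accounts for this loss.

This one pair leaves open whether the loss goes with the aromatic ring itself or with the removal of the butyl chain, which a cyclohexyl or benzyl group on the same nitrogen could help to separate. It also leaves open how a substituted phenyl, such as a fluorophenyl, or a shorter chain such as propyl would fare at this position.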